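This account rests on a few compounds, and the source may have more. Where it says the series, first, only, none or still open, it means among the compounds named here.

Measured so far:
- compound 1, `CCOC(=O)[C@@H]1CCCN(S(=O)(=O)c2ccc(S(=O)(=O)N3CCCCC3)cc2)C1`, gives 3300 nM
- compound 2, `CC(C)c1noc(N2CCN(C(=O)[C@@H]3CCCN(S(=O)(=O)c4ccc(S(=O)(=O)NC5CC5)cc4)C3)CC2)n1`, gives 6700 nM

Both numbers come from a functional assay on BXPC-3 cells (Homo sapiens) for inhibition, read by MTT assay, with a stated time of 7 days; a higher number here means a weaker inhibitor, a lower number a stronger inhibitor. Compound 2 stands at the higher of the two numbers; compound 1, which differs from it in several places at once, sits at a lower number, and the gap between the two lies beyond the scatter. Among the measured compounds shown here, no single-point step between measured compounds is available.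

Compound 3, `CCC(CC)S(=O)(=O)c1ccc(S(=O)(=O)N2CCC[C@@H](C(=O)N3CCN(c4nc(C(C)C)no4)CC3)C2)cc1`, is not yet measured. It differs from compound 2 by pentan-3-yl in place of cyclopropylamino on a sulfonyl sulfur. For the measured compounds named here, the data hold no example of this kind of change at the sulfonyl sulfur, so the expectation rests only on the position of compound 2 in this assay.

For compound 3 the expected step of a 1.1-fold lower number from compound 2 to compound 3 (0.05 log units; within the scatter) is taken as none beyond the scatter. The estimate for compound 3 in this assay is 6000 nM, with a range from 2000 nM to 20000 nM.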

Compound 3, half-maximal inhibitory concentration: 120 nM
Beside the measured number, compound 3's estimate is 50-fold (1.70 log units) above it; the measured number lies below the stated range.
By their numbers in this assay, from the lowest: compound 3; then compound 1; then compound 2.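

At the sulfonyl sulfur whose other neighbour is aromatic carbon, the number in this assay responds strongly to a single change: pentan-3-yl in place of cyclopropylamino gives a 56-fold lower number from compound 2 to compound 3 (1.75 log units; beyond the scatter) and marks this position as one where the group matters. The earlier compounds shown here differed in several places at once, so they could not tie a shift of this size to this position alone. No measured finding explains the step.

The change removes the three-membered ring and the hydrogen-bond donor together, so the step does not show which of these differences matters, or whether the pentan-3-yl chain itself is responsible. A pentan-3-ylamino group would keep the chain and the donor, while a cyclopropyl group directly on the sulfonyl sulfur would keep the ring without the donor, so these two would begin to separate the effects.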